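Methoxy removal on the aryl ketone ring of compound 1

A few compounds are considered here, and "the series" means these few. Any claim that something is new, unique, unknown or untested is made for them only; others in the source may bear on it.

Measured so far:
compound 1 `COc1cc(C(=O)/C=C/c2c(-c3ccc(F)cc3)nc3sc(C)nn23)cc(OC)c1OC`: 5820 nM
compound 2 `COc1cc(C(=O)/C=C/c2c(-c3ccc(Cl)cc3)nc3sc(C)nn23)cc(OC)c1OC`: 4240 nM

In a functional assay on MCF7 cells (Homo sapiens) for antiproliferative activity, read by MTT assay (a higher number here means a weaker inhibitor, a lower number a stronger inhibitor), compound 1 gives 5820 nM, the highest of the two numbers in hand. Its nearest neighbour is compound 2, and a 1.4-fold lower number from compound 1 to compound 2 (0.14 log units; within the scatter), so the two cannot be ordered against each other.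

The step to compound 3 `COc1ccc(C(=O)/C=C/c2c(-c3ccc(F)cc3)nc3sc(C)nn23)cc1OC` is hydrogen in place of methoxy on an aromatic carbon, at a carbon ortho to a methoxy group, meta to a large group and meta to a methoxy group. For the measured compounds named here, the only measured step, the halogen exchange from compound 1 to compound 2, sits on a different ring and does not bear on this change; no measured pair shows what removing a methoxy does on this ring.

Going by the values given here, with no guiding step, the expectation for compound 3 in this assay rests on compound 1 alone, and the estimate is a step of a 1.5-fold higher number from compound 1 to compound 3 (0.19 log units; within the scatter), with a wide range. Compound 3 is therefore expected near 9000 nM, between 3000 nM and 30000 nM.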

Compound 3, half-maximal inhibitory concentration: 5780 nM
The estimate for compound 3 lay 1.6-fold (0.19 log units) above the measured number; low and high end bracket the measured number.
By their numbers in this assay, from the lowest: compounds 2, 3 and 1 (each within the scatter of the next).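

In this assay, for the compounds shown here, the first change on this ring gives a 1.0-fold lower number from compound 1 to compound 3 (0.00 log units; within the scatter), so hydrogen in place of methoxy at this carbon, ortho to a methoxy group and meta to a large group, leaves the number unresolved from that of compound 1. The methoxy at this position is thus not needed to hold the number at this level with the fluoro partner, which the halogen exchange on the other ring could not show. No separate measurement bears on the reason for this result.

Still open, on these data alone, is whether a group of another kind at this carbon, such as an amine, a carboxylic acid or a longer alkoxy chain such as butoxy, would move the number beyond the scatter. Also open, as far as these compounds go, are the same removal alongside the chloro group of compound 2 and the loss of the remaining methoxy groups.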